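The source may report more compounds than this note shows. Statements on the series, on what has been measured and on what is new or still open speak of the compounds shown alone.

Measured so far:
compound 1 `COc1cc(-c2nn(-c3cccc(NC(=O)Nc4ccc(Cl)c(Cl)c4)c3)cc2-c2ccncc2)ccc1Cl` — > 50000 nM
compound 2 `COc1cc(-c2nn(-c3cccc(NC(=O)Nc4ccc(Cl)c(C(F)(F)F)c4)c3)cc2-c2ccncc2)ccc1Cl` — 9240 nM

Among the measured compounds shown here, in a functional assay on SNB-19 cells (Homo sapiens) for inhibition, read by sulforhodamine B assay, with a stated time of 48 h (on this read-out higher numbers stand for weaker inhibition of growth and lower numbers for stronger inhibition of growth), compound 2 gives 9240 nM, the only number in the set. For compound 1 the value > 50000 nM is a limit of the assay, not a number (the limit of > 50000 nM in this assay, at which 1 of the 2 values shown sits). For the measured compounds named here, the one measured step is an at least 5.4-fold lower number from compound 1 to compound 2 (0.73 log units; beyond the scatter), a change confined to one substituent on the aryl urea.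

Compound 3 `COc1cc(-c2nn(-c3cccc(NC(=O)c4ccccc4)c3)cc2-c2ccncc2)ccc1Cl` differs from compound 2 by phenyl in place of (4-chloro-3-(trifluoromethyl)phenyl)amino on a carbonyl carbon. The measured step concerns a substituent on the very ring that this change removes, so it bears on the new step only indirectly: it shows that the aryl urea end is sensitive to change, but gives no direct reading for replacing it with a plain benzamide. A weaker result than for compound 2 is expected. For compound 3 the estimate is 30000 nM, with a range from 9000 nM to 100000 nM. This corresponds to an expected step of a 3.2-fold higher number from compound 2 to compound 3 (0.51 log units; beyond the scatter).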

Compound 3, concentration for total growth inhibition: > 100000 nM
Compound 3: no number, only a limit; the forecaster's own chance of this, stated with the estimate: 45%; at least 3.3-fold (0.52 log units) between middle value and limit.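

In this assay, among the compounds shown here, phenyl in place of (4-chloro-3-(trifluoromethyl)phenyl)amino on the carbonyl carbon gives an at least 10-fold higher number from compound 2 to compound 3 (1.03 log units; beyond the scatter), so replacing the whole group now has a reading, where the earlier step covered only one substituent on its ring. For compound 3 the value is a limit of the assay, not a number: the limit of > 100000 nM in this assay, at which 1 of the 3 values shown sits. Compound 1 and compound 3 both stand at limits, and the step between them cannot be read.

Compound 3 loses the amide-type hydrogen of the leaving amino group and the chloro and trifluoromethyl substituents together, so the compounds shown do not separate their contributions. Also open, as far as these compounds go, is how an aliphatic amine on the carbonyl carbon, such as dimethylamino or morpholine, reads against the aryl urea of compound 2.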